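Dimethylamino for hydroxy on the carbonyl carbon

The source may report more compounds than this note shows. Statements on the series, on what has been measured and on what is new or still open speak of the compounds shown alone.

Compound 1 `CCc1cc(C(C)=O)c(O)cc1OCCCCCCC(C)(C)C#N` and compound 2 `CCc1cc(C(C)=O)c(O)cc1OCCCCCCC(=O)O` share one core and differ only at the end of the chain. In an assay on isolated protein for binding affinity to leukotriene B4 receptor 1 (Homo sapiens), tested at 1 uM (on this read-out higher numbers stand for more inhibition at the one concentration tested (going by the name of the read-out) and lower numbers for less inhibition), compound 1 gives 30%, and compound 2 gives 38%; the step of a number 8 percentage points higher from compound 1 to compound 2 (within the scatter) stays within the scatter. Compound 2 thus stands at the larger of the two numbers, with compound 1 within the scatter of it, so no order between them can be claimed.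

Compound 3 `CCc1cc(C(C)=O)c(O)cc1OCCCCCCC(=O)N(C)C` differs from compound 2 by dimethylamino in place of hydroxy on a carbonyl carbon. Among the compounds with values here, no measured step replaces hydroxy by dimethylamino on a carbonyl carbon. Within the data shown here, the only step on record, a number 8 percentage points higher from compound 1 to compound 2 (within the scatter), exchanges the whole chain end and was within the scatter, which shows that the carboxy of compound 2 is not demonstrably needed for the read-out in this assay. From the compounds shown here alone, on that basis a step of about a number 8 percentage points lower from compound 2 to compound 3 (within the scatter) is expected, that is none beyond the scatter, with a wide range because the change is untested. Compound 3 is estimated at 30%, between 10% and 55%.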

Compound 3, a percentage reported as inhibition, at one concentration (the size of the read-out at that concentration, not a potency): 61%
Compound 3: the middle estimate sits 31 percentage points below what was measured, and the stated range ends below it.
By their numbers in this assay, from the lowest: compounds 1 and 2 (each within the scatter of the next); then compound 3.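

In this assay, the end of the chain now responds beyond the scatter: dimethylamino in place of hydroxy on a carbonyl carbon gives a number 23 percentage points higher from compound 2 to compound 3 (beyond the scatter), a change the earlier pair of compounds could not reveal. Exchanging the whole chain end, with dimethylcarbamoyl in place of 1-cyano-1-methylethyl, gives a number 31 percentage points higher from compound 1 to compound 3 (beyond the scatter), so compound 3 stands clear of both other compounds, while compound 1 and compound 2 remain without an order, and a free carboxy is not required for the highest number in this small set. No measurement on hand accounts for this gain, and the change itself combines the loss of a hydroxy donor with the gain of more heavy atoms, which the data do not separate.

From the compounds shown here alone, how a primary carboxamide, a monomethyl amide or a pyrrolidine amide would read on the same carbonyl carbon stays open, so it cannot yet be said whether the gain belongs to dimethylamino specifically or to amides more broadly. Also open, going by these compounds, is whether dimethylcarbamoyl would hold its number on a shorter or a longer chain, and what potency lies behind a read-out taken at a single concentration.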